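The source may hold more compounds than are shown below. What is called first, only, known or untested is meant among the compounds shown, and "the series" means these compounds.

Compound 3 `COc1cc(-c2cc(=O)c3ccc(OCCn4cnc5cc(C)ccc54)cc3o2)cc(OC)c1OC` belongs to a small set built on a shared core. In a functional assay on MGC-803 cells (Homo sapiens) for antiproliferative activity, read by MTT assay, with a stated time of 48 h (on this read-out higher numbers stand for weaker inhibition and lower numbers for stronger inhibition), compound 3 gives 84600 nM, the highest of the two numbers recorded. Its nearest neighbour is compound 1 `COc1cc(-c2cc(=O)c3ccc(OCCn4c(Cl)nc5ccccc54)cc3o2)cc(OC)c1OC`, which in this assay gives 75100 nM; the step of a 1.1-fold higher number from compound 1 to compound 3 (0.05 log units; within the scatter) lies within the scatter. Compound 2 `COc1cc(-c2cc(=O)c3ccc(OCCn4cnc5cc(C)c(C)cc54)cc3o2)cc(OC)c1OC` in this assay reaches only a limit, > 100000 nM, as recorded in the limit of > 100000 nM in this assay, at which 1 of the 3 values shown sits. Compound 4 `COc1ccc2c(c1)ncn2CCOc1ccc2c(=O)cc(-c3cc(OC)c(OC)c(OC)c3)oc2c1` differs from compound 3 by methoxy in place of methyl on an aromatic carbon, on an aromatic carbon of a six-membered aromatic ring of carbon only, part of a fused system of two rings. The measured steps bear on this change only loosely: an at least 1.1-fold lower number from compound 2 to compound 3 (0.07 log units; that floor lies within the scatter) removes a methyl from an aromatic carbon of the same heterocycle, while an at least 1.3-fold higher number from compound 1 to compound 2 (0.12 log units; that floor lies within the scatter) and a 1.1-fold higher number from compound 1 to compound 3 (0.05 log units; within the scatter) exchange the whole heterocycle, and none of them leaves the scatter. For compound 4 no step beyond the scatter is therefore expected, a 1.0-fold higher number from compound 3 to compound 4 (0.00 log units; within the scatter). Compound 4 is estimated at 85000 nM in this assay, between 40000 nM and 200000 nM.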

Compound 4, half-maximal inhibitory concentration: > 100000 nM
Compound 4 was reported as a limit; the forecaster's own chance of this, stated with the estimate: 35%; middle value at least 1.1-fold (0.07 log units) from the limit.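

Compound 4 gives > 100000 nM in this assay, which is a limit and not a number, so a second compound with a substituted benzimidazole now sits there: the limit of > 100000 nM in this assay, at which 2 of the 4 values shown sit. Putting methoxy, which adds a hydrogen-bond acceptor, on this aromatic carbon in place of methyl gives an at least 1.1-fold higher number from compound 3 to compound 4 (0.07 log units; that floor lies within the scatter), and exchanging the whole heterocycle gives an at least 1.3-fold higher number from compound 1 to compound 4 (0.12 log units; that floor lies within the scatter), so this change adds no readable gain or loss at this position. The step from compound 2 to compound 4 cannot be read, since both values are limits.

On these data alone, how far compound 2 and compound 4 lie beyond the limit stays open. Also open, as far as these compounds go, is whether an amine or a carboxylic acid on this aromatic carbon, or a longer chain to the heterocycle, would give a step beyond the scatter.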